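The source may report more compounds than this note shows. Statements on the series, on what has been measured and on what is new or still open speak of the compounds shown alone.

In an ADME assay on Huh-7 cells (Homo sapiens) for cytotoxicity, with a stated time of 72 h (on this read-out lower numbers stand for higher toxicity in this test and higher numbers for lower toxicity in this test), compound 2 `CS(=O)(=O)Nc1ccc2c(c1)S(=O)(=O)N=C(C1=C(O)[C@H]3CCC[C@H]3N(Cc3ccc(F)c(F)c3)C1=O)N2` gives > 1000 nM, which is a limit and not a number, so its standing is known only as that limit. Compound 1 `CS(=O)(=O)Nc1ccc2c(c1)S(=O)(=O)N=C(C1=C(O)C3CCCC3N(CCC3CC3)C1=O)N2` gives > 33000 nM, also a limit. Compound 3 `CC(C)CCN1C(=O)C(C2=NS(=O)(=O)c3cc(NS(C)(=O)=O)ccc3N2)=C(O)[C@H]2CCC[C@H]21` differs from compound 2 in one place, isobutyl in place of 3,4-difluorophenyl on a saturated chain carbon bound to an amide-type nitrogen in a ring. Compound 1 also has no aromatic ring on that chain, so a large upward step is expected, a step that the limit leaves unreadable from compound 2 to compound 3, toward lower toxicity. Compound 3 is estimated at 25000 nM, with an expected range of 5000 nM to 60000 nM.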

Compound 3, half-maximal cytotoxic concentration: > 1000 nM
Compound 3 ended at the assay's limit; the forecaster's own chance of this, stated with the estimate: 85%; the middle value lies beyond the limit too.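

Compound 2 and compound 3 both end at a limit, not a number, so no step can be read between them. On these data alone, whether isobutyl and 3,4-difluorophenyl differ at all in this assay stays open.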